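The compounds below may be only part of what the source reports. "The series", "measured", "known", "first", "only" and "open" are said of these compounds alone.

Measured compounds in a functional assay on RKE cells for antagonist activity at Vasoactive intestinal polypeptide receptor 1 (Rattus norvegicus), read by HTRF and cAMP accumulation, with stated times of 10 min and 30 min; on this read-out higher numbers stand for weaker inhibition and lower numbers for stronger inhibition:
compound 1 `COc1ccc(-c2cc(C(C)(C)C)cc(C(C)C)c2CO)cc1`, giving 1300 nM
compound 2 `Cc1ccc(-c2cc(C(C)(C)C)cc(C(C)C)c2CO)cc1`, giving 300 nM

Among the measured compounds shown here, compound 2 holds the lower of the two numbers in this assay; the only step between them reads a 4.3-fold lower number from compound 1 to compound 2 (0.64 log units; beyond the scatter). Compound 3 `CC(C)c1cc(C(C)(C)C)cc(-c2ccc(Cl)cc2)c1CO` differs from compound 2 by chloro in place of methyl on an aromatic carbon, the position being para to a large group. For the measured compounds named here, the single measured step bears on it only loosely, as it swaps a different group at the same place, and it was modest. A step of roughly a 1.2-fold lower number from compound 2 to compound 3 (0.08 log units; within the scatter) is therefore expected, not clearly beyond the scatter. Compound 3 is estimated at 250 nM, with a range of 100 nM to 700 nM.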

Compound 3, half-maximal inhibitory concentration: 290 nM
The estimate for compound 3 lay 1.2-fold (0.06 log units) below the measured number, and the stated range covers the measured number.
By their numbers in this assay, from the lowest: compounds 3 and 2 (each within the scatter of the next); then compound 1.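

In this assay, chloro in place of methyl at this position, para to a large group, gives a 1.0-fold lower number from compound 2 to compound 3 (0.01 log units; within the scatter), so the two groups cannot be told apart here. Chloro also stands clear of methoxy, with a 4.5-fold lower number from compound 1 to compound 3 (0.65 log units; beyond the scatter), which makes methoxy the only one of the three groups that separates from the others. No evidence on hand bears on this result. Still open, as far as these compounds go, is whether an amine, a carboxylic acid or a longer chain at this position would hold the numbers of compound 2 and compound 3 or depart from them.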